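The source may hold more compounds than are shown below. What is called first, only, known or untested is meant among the compounds shown, and "the series" means these compounds.

The series shares one core, seen in compound 1 `CN1C(=O)C2(C(C#N)=C(N)Oc3cc4oc(-c5ccccc5)cc(=O)c4c(O)c32)c2cc(Br)ccc21`, which in a functional assay on NCI-H1299 cells (Homo sapiens) for antiproliferative activity, read by MTT assay, with a stated time of 48 h (on this read-out higher numbers stand for weaker inhibition and lower numbers for stronger inhibition), gives 7610 nM. Compound 2 `COc1ccc2c(c1)C1(C(=O)N2Cc2ccccc2)C(C#N)=C(N)Oc2cc3oc(-c4ccccc4)cc(=O)c3c(O)c21` carries a methoxy group and a benzyl group on the amide nitrogen; in this assay compound 2 reaches only the limit of the assay, > 50000 nM. Compound 3 `N#CC1=C(N)Oc2cc3oc(-c4ccccc4)cc(=O)c3c(O)c2C12C(=O)N(Cc1ccccc1)c1ccc(F)cc12` likewise reaches only the limit in this assay, > 50000 nM. The change from compound 2 to compound 3 gives a step that the two limits leave unreadable from compound 2 to compound 3, since both sit at the limit of > 50000 nM in this assay, at which 2 of the 3 values shown sit. Compound 3 thus stands at the limit, and nothing more exact can be said about it on the numbers shown.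

Compound 4 `N#CC1=C(N)Oc2cc3oc(-c4ccccc4)cc(=O)c3c(O)c2C12C(=O)N(Cc1ccccc1)c1ccc(Br)cc12` arises from compound 3 by bromo in place of fluoro on an aromatic carbon. Within the data shown here, no measured step covers a bromo-for-fluoro exchange directly. Among the measured compounds shown here, the only bromo compound, compound 1, has a methyl rather than a benzyl on the amide nitrogen and gives a number rather than a limit, whereas the step from compound 2 to compound 3 shows that the benzyl-bearing compounds have not yet produced a readable value. Compound 4 is therefore expected to land near the limit, with an at least 1.2-fold lower number from compound 3 to compound 4 (0.09 log units; that floor lies within the scatter) left uncertain. The estimate for compound 4 in this assay is 40000 nM, between 10000 nM and 60000 nM.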

Compound 4, half-maximal inhibitory concentration: > 50000 nM
Compound 4 gave a limit, no number (the forecaster's own chance of this, stated with the estimate: 60%); middle value at least 1.2-fold (0.09 log units) away from the limit.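

With bromo held in place, compound 1 and compound 4 differ only in the group on the amide nitrogen: in this assay, phenyl in place of hydrogen on the saturated chain carbon bound to that nitrogen gives an at least 6.5-fold higher number from compound 1 to compound 4 (0.81 log units; beyond the scatter). Among these compounds, this is the first readable step, and it sets the benzyl group of compound 4 against the methyl group of compound 1, with the same bromo on the aromatic carbon. The steps among compound 2, compound 3 and compound 4 cannot be read, so with the benzyl group present, methoxy, fluoro and bromo on the aromatic carbon cannot be told apart: the limit of > 50000 nM in this assay, at which 3 of the 4 values shown sit.

As far as these compounds go, it remains open whether fluoro or methoxy on the aromatic carbon would give a number above or below that of compound 1 if the methyl group stayed on the amide nitrogen. From the compounds shown here alone, it is equally open how an ethyl group, a longer chain or a chain ending in an amine on that nitrogen would read in this assay.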